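The source may hold more compounds than are shown below. What is called first, only, known or untested is meant among the compounds shown, and "the series" means these compounds.

Among the measured compounds shown here, compound 2 `CCCCCCCCCCCCCCOC(=O)c1cc(O)c(O)c(O)c1` carries the highest of the two numbers so far, though only within the scatter of its neighbour. In a functional assay on B16-F10 cells (Mus musculus) for cytotoxicity (on this read-out lower numbers stand for stronger inhibition and higher numbers for weaker inhibition), compound 2 gives 60000 nM. The nearest measured compound is compound 1 `CCCCCCCCOC(=O)c1cc(O)c(O)c(O)c1`, and in this assay compound 1 gives 45000 nM. For the measured compounds named here, the one step between them, a 1.3-fold higher number from compound 1 to compound 2 (0.12 log units; within the scatter), did not reach beyond the scatter.

Compound 3 `CCCCCCCCCCOC(=O)c1cc(O)c(O)c(O)c1` differs from compound 2 by hydrogen in place of butyl on a saturated chain carbon, ten or more bonds along the chain from an oxygen next to a carbonyl group. Going by the values given here, the only measured step that bears on this change is the chain variation from compound 1 to compound 2, and it stayed within the scatter. No shift beyond the scatter is therefore expected for compound 3 in this assay. The expected step for compound 3 is a 1.2-fold lower number from compound 2 to compound 3 (0.08 log units; within the scatter). Compound 3 is estimated at 50000 nM, with a range from 25000 nM to 100000 nM.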

Compound 3, half-maximal inhibitory concentration: 82000 nM
Compound 3: the middle estimate sits 1.6-fold (0.21 log units) below what was measured, and the stated range covers the measured number.
By their numbers in this assay, from the lowest: compounds 1, 2 and 3 (each within the scatter of the next).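

Hydrogen in place of butyl on a saturated chain carbon gives a 1.4-fold higher number from compound 2 to compound 3 (0.14 log units; within the scatter), so a change at this place also stays within the scatter. The remaining pair of chains gives a 1.8-fold higher number from compound 1 to compound 3 (0.26 log units; within the scatter), which leaves all three chains within the scatter of one another in this assay, with no trend to read from them. Nothing available explains these numbers.

Open, going by these compounds, is whether a longer chain would give a step beyond the scatter. Also open, on these data alone, is whether an amine or a carboxylic acid on a saturated chain carbon would do so.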